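The source may hold more compounds than are shown below. What is called first, only, known or untested is meant among the compounds shown, and "the series" means these compounds.

In a functional assay on HepG2 cells (Homo sapiens) for cytotoxicity, read by MTT assay, with a stated time of 24 h (on this read-out higher numbers stand for weaker inhibition and lower numbers for stronger inhibition), compound 1 (`C/C(=N\OCC(=O)N[C@H](C(=O)N[C@@H](CCCCN)C(=O)N1CCC[C@H]1C(=O)N[C@@H](CCCCN)C(=O)NCC(N)=O)[C@@H](C)O)c1ccc(NC(=O)c2cc(Br)ccc2O)cc1`) gives > 200000 nM, which is a limit and not a number. Compound 2 (`C/C(=N\OCC(=O)NCC(=O)O)c1ccc(NC(=O)c2cc(Br)ccc2O)cc1`) gives > 200000 nM, also a limit. Compound 2 therefore stands at the limit of > 200000 nM in this assay, at which 2 of the 2 values shown sit. Compound 3 (`C/C(=N\OCC(=O)N[C@H](C(=O)O)[C@@H](C)O)c1ccc(NC(=O)c2cc(Br)ccc2O)cc1`) carries 1-hydroxyethyl in place of hydrogen on a saturated chain carbon bound to an amide-type nitrogen and a carbonyl carbon. For the measured compounds named here, no measured pair shows this change, so no step beyond the scatter is expected in this assay, in either direction. The estimated step is a step that the limit leaves unreadable from compound 2 to compound 3. Compound 3 is expected at 220000 nM, within an estimated range of 120000 nM to 400000 nM.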

Compound 3, half-maximal inhibitory concentration: > 200000 nM
Compound 3 was reported as a limit; the forecaster's own chance of this, stated with the estimate: 85%; the middle value is on the limit's open side.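

Compound 2 and compound 3 are both reported only as limits, so no step can be read between them: the limit of > 200000 nM in this assay, at which 3 of the 3 values shown sit.

Whether 1-hydroxyethyl in place of hydrogen changes the read-out at all remains open, and none of the compounds shown has an exact value.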